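The source may report more compounds than this note shows. Statements on the series, on what has been measured and on what is new or still open speak of the compounds shown alone.

In a functional assay on P388 cells (Mus musculus) for cytotoxicity (on this read-out lower numbers stand for stronger inhibition and higher numbers for weaker inhibition), compound 2 (`COc1ccc(C[C@H]2C(=O)N[C@@H](C)C(=O)N(C)[C@H]3Cc4ccc(cc4)Oc4cc(ccc4OC)C[C@@H](C(=O)N[C@H](C)C(=O)N[C@@H](CCCO)C(=O)N2C)N(C)C3=O)cc1`) gives 174 nM, the middle of three values. Compound 1 (`COc1ccc(C[C@H]2C(=O)N[C@@H](C)C(=O)N(C)[C@H]3Cc4ccc(cc4)Oc4cc(ccc4OC)C[C@@H](C(=O)N[C@H](C)C(=O)NC4(SCCS4)C(=O)N2C)N(C)C3=O)cc1`) gives 631 nM and compound 3 (`COc1ccc(C[C@H]2C(=O)N[C@@H](C)C(=O)N(C)[C@H]3Cc4ccc(cc4)Oc4cc(ccc4OC)C[C@@H](C(=O)N[C@H](C)C(=O)N[C@@H](CCCN=[N+]=[N-])C(=O)N2C)N(C)C3=O)cc1`) gives 35.5 nM. Compound 4 (`C=C[C@@H]1NC(=O)[C@@H](C)NC(=O)[C@@H]2Cc3ccc(OC)c(c3)Oc3ccc(cc3)C[C@@H](C(=O)N2C)N(C)C(=O)[C@H](C)NC(=O)[C@H](Cc2ccc(OC)cc2)N(C)C1=O`) carries vinyl in place of 3-hydroxypropyl on a saturated ring carbon. Going by the values given here, one measured step bears on this change, a 4.9-fold lower number from compound 2 to compound 3 (0.69 log units; beyond the scatter), a modest step in which azido replaces the hydroxy while the chain stays. Among the compounds with values here, compound 4 also loses that hydroxy, but it loses the chain as well, and no measured compound carries vinyl, so the guide is partial. A modest move towards a lower number is therefore expected, with the estimated step being a 2.9-fold lower number from compound 2 to compound 4 (0.46 log units; beyond the scatter). In this assay, compound 4 is expected at 60 nM, within an estimated range of 18 nM to 200 nM.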

Compound 4, half-maximal inhibitory concentration: 25.7 nM
Compound 4: the middle estimate sits 2.3-fold (0.37 log units) above what was measured, within the range that was stated.
By their numbers in this assay, from the lowest: compounds 4 and 3 (each within the scatter of the next); then compound 2; then compound 1.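

In this assay, swapping 3-hydroxypropyl for vinyl gives a 6.8-fold lower number from compound 2 to compound 4 (0.83 log units; beyond the scatter) and shows that this saturated ring carbon needs neither the hydroxy nor the full chain for a low number. The change from 3-azidopropyl to vinyl gives a 1.4-fold lower number from compound 3 to compound 4 (0.14 log units; within the scatter) and so does not separate these two groups, despite their different lengths. No evidence is available to explain these steps. The compounds shown leave open whether the double bond matters, as an ethyl group would test. They also leave open how an amine or a carboxylic acid at the chain end would compare.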